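A tert-Butyl Group Takes the Place of a Cyano Group

A few compounds are considered here, and "the series" means these few. Any claim that something is new, unique, unknown or untested is made for them only; others in the source may bear on it.

Compound 1 `N#Cc1cc(C(=O)N2CCc3ccccc32)ccc1O` and compound 2 `N#Cc1cc(C(=O)N2CCc3ccccc32)cc(C#N)c1O` share one core. In an assay on tissue (RPTEC cells) for inhibition of solute carrier family 22 member 12 (Homo sapiens), read by scintillation counting, with stated times of 15 min and 2 h (a lower number here means a stronger inhibitor, a higher number a weaker inhibitor), compound 1 gives 2500 nM, while compound 2 gives 83900 nM, the highest of the two numbers. Within the data shown here, the only step seen so far is a 34-fold higher number from compound 1 to compound 2 (1.53 log units; beyond the scatter), a large one, and it is the single step that bears on the change now considered. Compound 3 `CC(C)(C)c1cc(C(=O)N2CCc3ccccc32)cc(C#N)c1O` differs from compound 2 by tert-butyl in place of cyano on an aromatic carbon. Nothing measured shows what a tert-butyl group does at this position; the step from compound 1 to compound 2 only shows that placing a cyano group there raised the number strongly, and removing it may undo some of that rise. Compound 3 is therefore expected to give a lower number than compound 2, with an estimated step of a 7.0-fold lower number from compound 2 to compound 3 (0.84 log units; beyond the scatter). The estimate for compound 3 is 12000 nM, between 2500 nM and 60000 nM.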

Compound 3, half-maximal inhibitory concentration: 31600 nM
Compound 3: middle estimate off by 2.6-fold (0.42 log units), on the low side, within the range that was stated.
By their numbers in this assay, from the lowest: compound 1; then compound 3; then compound 2.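

In this assay, the step of a 2.7-fold lower number from compound 2 to compound 3 (0.42 log units; beyond the scatter) shows that the high number at this position, ortho to a hydroxy group, does not depend on the cyano group alone, since tert-butyl in its place gives only a modest recovery. The step of a 13-fold higher number from compound 1 to compound 3 (1.10 log units; beyond the scatter) remains large, so tert-butyl still stands well short of the hydrogen carried by compound 1. Among these three compounds, then, both groups raise the number relative to hydrogen, cyano more so than tert-butyl. Nothing measured here explains this order. The compounds shown leave open what a methyl group, a chlorine atom, an amine or a carboxylic acid would do at this position, and whether any group there could give a lower number than hydrogen.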